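This account rests on a few compounds, and the source may have more. Where it says the series, first, only, none or still open, it means among the compounds named here.

Compound 1 `c1ccc2nc(N3CC(Oc4nccnc4N4CCCCC4)C3)ccc2c1` is the starting point. In a physicochemical assay for solubility, in phosphate buffer, at pH 7.4 (a higher number here means a more soluble compound, a lower number a less soluble compound), compound 1 gives only a limit, < 1000 nM, so it stands at the limit of < 1000 nM in this assay, at which 1 of the 3 values shown sits, rather than at a measured number. Compound 2 `OCc1cccc(-c2nccnc2OC2CN(c3ccc4ccccc4n3)C2)c1` gives 29000 nM in this assay, and compound 3 `c1ccc2nc(N3CC(Oc4nccnc4-c4cncnc4)C3)ccc2c1` gives 254000 nM. Compound 4 `c1ccc2nc(N3CC(Oc4nccnc4-c4cccc5ncccc45)C3)ccc2c1` changes the same group at the same place as those two: quinolin-5-yl in place of piperidin-1-yl on an aromatic carbon. Given an at least 29-fold higher number from compound 1 to compound 2 (1.46 log units; beyond the scatter) and an at least 250-fold higher number from compound 1 to compound 3 (2.40 log units; beyond the scatter), a rise beyond the scatter is expected for compound 4 as well, though a new aromatic group gives no direct guide to its size. For compound 4 the estimate in this assay is 10000 nM, within a range from 1000 nM to 80000 nM, meaning an expected step of an at least 10-fold higher number from compound 1 to compound 4 (1.00 log units; beyond the scatter).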

Compound 4, solubility: 47000 nM
Beside the measured number, compound 4's estimate is 4.7-fold (0.67 log units) below it; low and high end bracket the measured number.
By their numbers in this assay, from the lowest: compounds 2 and 4 (each within the scatter of the next); then compound 3. At a limit, below all of these: compound 1.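

Quinolin-5-yl, a third aromatic group on this carbon next to the ring nitrogen, also raises the number in this assay, with an at least 47-fold higher number from compound 1 to compound 4 (1.67 log units; beyond the scatter). Which aromatic group sits here still matters, with a 5.4-fold lower number from compound 3 to compound 4 (0.73 log units; beyond the scatter), whereas a 1.6-fold higher number from compound 2 to compound 4 (0.21 log units; within the scatter). The first of these steps has no exact size, as compound 1 stands at a limit and not at a measured number: the limit of < 1000 nM in this assay, at which 1 of the 4 values shown sits.

The compounds shown leave open whether an open-chain amine or a carboxylic acid on this carbon would raise the number as the aromatic groups do. They also leave open whether the rise comes from losing piperidin-1-yl or from gaining an aromatic ring.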